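The source may hold more compounds than are shown below. What is called first, only, known or untested is meant among the compounds shown, and "the series" means these compounds.

Measured so far:
Compound 1, `CCCCOC(=O)Nc1ccc([Se]C#N)cc1`: 40800 nM
Compound 2, `O=C(Nc1ccc([Se][Se]c2ccc(NC(=O)OCc3ccc([N+](=O)[O-])cc3)cc2)cc1)OCc1ccc([N+](=O)[O-])cc1`: 27100 nM

In a functional assay on PC-3 cells (Homo sapiens) for cytotoxicity, read by MTT assay, with a stated time of 72 h (a lower number here means a stronger inhibitor of growth, a higher number a weaker inhibitor of growth), compound 1 gives 40800 nM, the higher of the two numbers recorded. Compound 2 gives 27100 nM, and the gap between these two values lies within the usual scatter of repeated measurements, so no order between compound 1 and compound 2 can be read from them. The two structures differ in several places at once, so nothing about any single change can be drawn from this pair.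

Compound 3, `N#C[Se]c1ccc(NC(=O)OCc2ccccc2)cc1`, has not been measured. It differs from compound 1 in one place only: phenyl in place of propyl on a saturated chain carbon bound to an oxygen next to a carbonyl group. Within the data shown here, no measured pair shows what this change does. Nothing in the measured compounds points in either direction, so the step is expected to stay within the scatter: a 1.2-fold lower number from compound 1 to compound 3 (0.07 log units; within the scatter). Compound 3 is therefore expected to give about 35000 nM in this assay, with a range from 12000 nM to 100000 nM.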

Compound 3, concentration for total growth inhibition: 27800 nM
For compound 3 the middle estimate is 1.3-fold (0.10 log units) above the measured one; low and high end bracket the measured number.
By their numbers in this assay, from the lowest: compounds 2, 3 and 1 (each within the scatter of the next).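

In this assay, among these compounds, phenyl in place of propyl on a saturated chain carbon bound to an oxygen next to a carbonyl group gives a 1.5-fold lower number from compound 1 to compound 3 (0.17 log units; within the scatter), the first step between measured compounds that differ in one place. It shows that, at this place, a six-membered aromatic ring of carbon can stand in for an open chain without a difference that can be told from the scatter. No measurement shown here bears on what lies behind this result.

Still open, going by these compounds, is whether a different group at this place, such as an amine or a longer chain, would shift the number beyond the scatter. A single step within the scatter also cannot show whether any group here matters for growth inhibition in these cells.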